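The source may report more compounds than this note shows. Statements on the series, on what has been measured and on what is new or still open speak of the compounds shown alone.

Compound 1, `CC#CCCOc1cccc2ccc(N)nc12`, gives in an assay on cells with melanin-concentrating hormone receptor 1 (Homo sapiens) as the target, read by radioligand binding (a higher number here means a weaker inhibitor, a lower number a stronger inhibitor), only a limit, > 2000 nM.
Compound 2, `Nc1ccc2cccc(OC3CCCCCC3)c2n1`, gives in this assay 137 nM.

Compound 1 therefore stands at the limit of > 2000 nM in this assay, at which 1 of the 2 values shown sits, so its position on the scale is known only as a limit, while compound 2 sits at a measured number. Compound 3, `Nc1ccc2cccc(OCCC3CC3)c2n1`, departs from compound 1 by cyclopropyl in place of prop-1-yn-1-yl on a saturated chain carbon, two bonds along the chain from an oxygen on an aromatic ring. Among the measured compounds shown here, no measured step connects these two compounds. For the measured compounds named here, the ring-bearing ether of compound 2 gives the one measured number here, so a step toward stronger inhibition beyond the usual scatter is expected for compound 3, an at least 2.5-fold lower number from compound 1 to compound 3 (0.39 log units; beyond the scatter). Compound 3 is estimated at 800 nM, within 200 nM to 4000 nM.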

Compound 3, half-maximal inhibitory concentration: 492 nM
Beside the measured number, compound 3's estimate is 1.6-fold (0.21 log units) above it; measured number inside the range.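

Replacing prop-1-yn-1-yl with cyclopropyl, each of 3 heavy atoms, on a saturated chain carbon, two bonds along the chain from an oxygen on an aromatic ring, gives an at least 4.0-fold lower number from compound 1 to compound 3 (0.60 log units; beyond the scatter) in this assay. At this place, then, the identity of the group matters even when the heavy-atom count stays the same. The step has a lower bound only, as it starts from a limit: the limit of > 2000 nM in this assay, at which 1 of the 3 values shown sits.

On these data alone, whether a cyclobutyl or phenyl group at this place would lower the number further stays open. So does the effect of a longer chain ending in cyclopropyl, or of an amine there.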